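Swapping a Hydroxyphenyl for a Pyridinyl Group

The source may report more compounds than this note shows. Statements on the series, on what has been measured and on what is new or still open speak of the compounds shown alone.

Of the compounds shown here, two sharing one core have been tested in an assay on isolated protein for inhibition of aldehyde dehydrogenase 1A1 (Homo sapiens); on this read-out lower numbers stand for stronger inhibition and higher numbers for weaker inhibition. Compound 1 `COc1ccc(C(C)Sc2nc3c(cnn3C)c(=O)n2-c2ccccc2)cc1` carries a 4-methoxyphenyl group on a saturated chain carbon bound to a saturated chain carbon and a sulfur, and in this assay compound 1 gives 352 nM. Compound 2 `CC(Sc1nc2c(cnn2C)c(=O)n1-c1ccccc1)c1cccc(O)c1` carries a 3-hydroxyphenyl group at that same place, and in this assay compound 2 gives 130 nM. Among the compounds with values here, the single measured step shows a 2.7-fold lower number from compound 1 to compound 2 (0.43 log units; beyond the scatter). Within the data shown here, compound 2 thus stands at the lowest of the two numbers known so far.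

Compound 3 `CC(Sc1nc2c(cnn2C)c(=O)n1-c1ccccc1)c1cccnc1` has not yet been measured. It differs from compound 2 in one place: pyridin-3-yl in place of 3-hydroxyphenyl on a saturated chain carbon bound to a saturated chain carbon and a sulfur. Among the measured compounds shown here, no measured step mirrors this exact change; the only one available, a 2.7-fold lower number from compound 1 to compound 2 (0.43 log units; beyond the scatter), concerns a different pair of groups and bears on it only indirectly. For the measured compounds named here, the group that leaves carries the one hydrogen-bond donor that compound 1 also lacked, so a modest move back toward the number of compound 1 is expected, which would mean a 2.3-fold higher number from compound 2 to compound 3 (0.36 log units; beyond the scatter). Compound 3 is therefore estimated at 300 nM, within a range of 100 nM to 900 nM.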

Compound 3, half-maximal inhibitory concentration: 139 nM
The estimate for compound 3 lay 2.2-fold (0.33 log units) above the measured number; measured number inside the range.
By their numbers in this assay, from the lowest: compounds 2 and 3 (each within the scatter of the next); then compound 1.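

In this assay, replacing 3-hydroxyphenyl with pyridin-3-yl on the saturated chain carbon gives a 1.1-fold higher number from compound 2 to compound 3 (0.03 log units; within the scatter), so this assay does not separate these two groups at this place. Until now, only compound 2 stood apart from compound 1, and the hydrogen-bond donor of its 3-hydroxyphenyl group was an obvious candidate for the difference, but pyridin-3-yl has 0 hydrogen-bond donors and still gives a 2.5-fold lower number from compound 1 to compound 3 (0.40 log units; beyond the scatter), which shows that a donor in this group is not required to reach this level. No available evidence explains why the two groups read alike.

Both 3-hydroxyphenyl and pyridin-3-yl count 1 hydrogen-bond acceptor, so the compounds shown leave open whether that shared feature matters, and a plain phenyl group, with neither the oxygen nor the ring nitrogen, would test this directly. They also leave open how far this place tolerates other groups, such as pyridin-4-yl, 3-aminophenyl or 3-methoxyphenyl, the last of which would help show whether the step from compound 1 depends on the methoxy group or on where it sits.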